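This account rests on a few compounds, and the source may have more. Where it says the series, first, only, none or still open, it means among the compounds named here.

Compound 3, `CCCCC(=O)O[C@H]1C[C@@H](C)C=C2C=C[C@H](C)[C@H](CC[C@@H]3C[C@@H](O)CC(=O)O3)C21`, is an ester in which a butylcarbonyl group sits on the shared core. Among the compounds with values here, in an assay for inhibition of 3-hydroxy-3-methylglutaryl-coenzyme A reductase (Rattus norvegicus) (a lower number here means a stronger inhibitor, a higher number a weaker inhibitor), compound 3 gives 8.7 nM, which places it second highest among the three numbers so far. Its closest neighbour is compound 1, `CC(C)C(=O)O[C@H]1C[C@@H](C)C=C2C=C[C@H](C)[C@H](CC[C@@H]3C[C@@H](O)CC(=O)O3)C21`, which gives 7.7 nM; the change a 1.1-fold higher number from compound 1 to compound 3 (0.05 log units; within the scatter) lies within the scatter, so the two cannot be told apart. Far from both stands compound 2, `CC(=O)O[C@H]1C[C@@H](C)C=C2C=C[C@H](C)[C@H](CC[C@@H]3C[C@@H](O)CC(=O)O3)C21`, which gives 269 nM; here a 31-fold lower number from compound 2 to compound 3 (1.49 log units; beyond the scatter) is a large step, and the matching comparison a 35-fold higher number from compound 1 to compound 2 (1.54 log units; beyond the scatter) shows that cutting the ester down to a methyl on the carbonyl carbon costs a great deal.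

Compound 4, `C=C(C)CC(=O)O[C@H]1C[C@@H](C)C=C2C=C[C@H](C)[C@H](CC[C@@H]3C[C@@H](O)CC(=O)O3)C21`, differs from compound 3 by 1-methylethenyl in place of propyl on a saturated chain carbon bound to a carbonyl carbon. The two large measured steps both involve shrinking the ester to its smallest form, whereas the step between compound 1 and compound 3, which keeps the ester group at a similar count of atoms, stays within the scatter. The change to compound 4 likewise keeps the count of the group unchanged, so no step beyond the scatter is expected; the estimated change is a 1.1-fold higher number from compound 3 to compound 4 (0.06 log units; within the scatter). Compound 4 is therefore expected to give about 10 nM in this assay, within a range from 4 nM to 25 nM.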

Compound 4, half-maximal inhibitory concentration: 2.9 nM
Beside the measured number, compound 4's estimate is 3.4-fold (0.54 log units) above it; the measured number lies below the stated range.
By their numbers in this assay, from the lowest: compound 4; then compounds 1 and 3 (each within the scatter of the next); then compound 2.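

In this assay, this ester position turns out to respond to more than the count of atoms: propyl and 1-methylethenyl hold the same number of heavy atoms, yet replacing the first with the second, which brings in a branch and a double bond, gives a 3.0-fold lower number from compound 3 to compound 4 (0.48 log units; beyond the scatter). The same change in the ester also separates compound 4 from compound 1, with 2-methylprop-2-en-1-yl in place of isopropyl on the carbonyl carbon giving a 2.7-fold lower number from compound 1 to compound 4 (0.42 log units; beyond the scatter), whereas butyl in that place stayed within the scatter, and the gap from the methyl ester widens to a 93-fold lower number from compound 2 to compound 4 (1.97 log units; beyond the scatter). No measurement at hand accounts for the stronger inhibition seen with this unsaturated group.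

Going by these compounds, it remains open whether the branch or the double bond carries the change, and a saturated 2-methylpropyl on the carbonyl carbon would keep the branch while removing the double bond. On these data alone, how a longer chain, a phenyl ring or an amine would fare on that carbonyl carbon also remains unknown from these compounds.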